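The compounds below may be only part of what the source reports. "The series", "measured", "known", "first", "only" and "open" are said of these compounds alone.

Measured in an ADME assay on Jurkat cells (Homo sapiens) for cytotoxicity, read by MTT assay; a lower number here means a stronger inhibitor, a higher number a weaker inhibitor:
Compound 1 `O/N=C(\COc1cccc2ccccc12)c1ccccc1`: > 50000 nM, a limit of the assay.
Compound 2 `O/N=C(\COc1cccc2ccccc12)c1ccc(Br)cc1`: > 50000 nM, a limit of the assay.
Compound 3 `COc1ccc(/C(COc2cccc3ccccc23)=N/O)cc1`: 31800 nM.

Within the data shown here, compound 3 gives the only actual number in this set. The other two stand at the limit of > 50000 nM in this assay, at which 2 of the 3 values shown sit.

Compound 4 `O/N=C(\COc1cccc2ccccc12)c1ccc(C(F)(F)F)cc1` has trifluoromethyl in place of methoxy on an aromatic carbon, para to a large group: trifluoromethyl in place of methoxy on an aromatic carbon.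

Among the measured compounds shown here, two measured steps bear on this change: an at least 1.5-fold lower number from compound 1 to compound 3 (0.19 log units; that floor lies within the scatter) and an at least 1.5-fold lower number from compound 2 to compound 3 (0.19 log units; that floor lies within the scatter). Both lead to compound 3 by gaining methoxy, and neither floor clears the scatter. The third step, a step that the two limits leave unreadable from compound 1 to compound 2, adds nothing on size. With methoxy gone, a somewhat higher number is expected in this assay, though perhaps none beyond the scatter, and a limit is quite possible. The expected change is a 1.4-fold higher number from compound 3 to compound 4 (0.15 log units; within the scatter). For compound 4 the estimated value is 45000 nM, with an expected range from 20000 nM to 90000 nM.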

Compound 4, half-maximal inhibitory concentration: > 50000 nM
Compound 4 was reported as a limit; the forecaster's own chance of this, stated with the estimate: 55%; at least 1.1-fold (0.04 log units) between middle value and limit.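

In this assay, trifluoromethyl in place of methoxy gives an at least 1.5-fold higher number from compound 3 to compound 4 (0.19 log units; that floor lies within the scatter), and the value of compound 4 is a limit, not a number. At this aromatic carbon, para to a large group, methoxy is now the only group of the four shown that gives a number, and the steps from compound 1 and compound 2 to compound 4 cannot be read. The set now gathers at one limit: the limit of > 50000 nM in this assay, at which 3 of the 4 values shown sit.

As far as these compounds go, the actual numbers for compound 1, compound 2 and compound 4 remain open. So does what an amine or a carboxylic acid at this carbon would give.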